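The compounds below may be only part of what the source reports. "The series", "measured", "known", "first", "only" and "open" are said of these compounds alone.

The series shares one core and is varied at the group on the thiocarbonyl carbon. For the measured compounds named here, compound 3 `Cc1cccc(/C(N)=N/NC(=S)N2CCCCC2)n1` carries piperidin-1-yl there; in a functional assay on A-431 cells (Homo sapiens) for cytotoxicity, read by MTT assay, with a stated time of 72 h (on this read-out lower numbers stand for stronger inhibition and higher numbers for weaker inhibition), compound 3 gives 12400 nM, the highest of the three numbers measured so far. Compound 1 `Cc1cccc(/C(N)=N/NC(=S)N2CCSCC2)n1`, with thiomorpholin-4-yl, gives 2600 nM in this assay, and compound 2 `Cc1cccc(/C(N)=N/NC(=S)N2CCOCC2)n1`, with morpholin-4-yl, gives 4300 nM. The steps of a 4.8-fold higher number from compound 1 to compound 3 (0.68 log units; beyond the scatter) and a 2.9-fold higher number from compound 2 to compound 3 (0.46 log units; beyond the scatter) both run beyond the scatter, whereas a 1.7-fold higher number from compound 1 to compound 2 (0.22 log units; within the scatter) does not.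

Compound 4 `Cc1cccc(/C(N)=N/NC(=S)N2CCCC2)n1` differs from compound 3 in one place: pyrrolidin-1-yl in place of piperidin-1-yl on a thiocarbonyl carbon. Going by the values given here, none of the measured steps exchanges a six-membered ring for a five-membered one; the steps to hand swap one hetero atom for another or for carbon within a six-membered ring, and they set compound 3 apart from compounds 1 and 2 without giving any direction for a ring contraction. Compound 3 therefore serves as the anchor, and no step beyond the scatter is foreseen. For compound 4 the expected step is a 1.0-fold lower number from compound 3 to compound 4 (0.01 log units; within the scatter). Compound 4 is estimated at 12000 nM in this assay, with a range from 5000 nM to 30000 nM.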

Compound 4, half-maximal inhibitory concentration: 4000 nM
Compound 4: middle estimate off by 3.0-fold (0.48 log units), on the high side; measured number outside the range, below it.
By their numbers in this assay, from the lowest: compounds 1, 4 and 2 (each within the scatter of the next); then compound 3.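

In this assay, for the compounds shown here, the step of a 3.1-fold lower number from compound 3 to compound 4 (0.49 log units; beyond the scatter) is the first change of ring size at this position, and it lies beyond the scatter, so the thiocarbonyl carbon responds to pyrrolidin-1-yl in place of piperidin-1-yl even though neither ring carries a second hetero atom. The steps of a 1.1-fold lower number from compound 2 to compound 4 (0.03 log units; within the scatter) and a 1.5-fold higher number from compound 1 to compound 4 (0.19 log units; within the scatter) both lie within the scatter, which leaves compound 3 alone as the weakest of the four, and ring size does not sort the series, since compounds 1 and 2 have six-membered rings yet stay level with compound 4. Nothing measured accounts for the piperidin-1-yl result.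

From the compounds shown here alone, it remains open how azepan-1-yl or an open-chain diethylamino group would read at this carbon. Piperazin-1-yl, with a second ring nitrogen, is equally open.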